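The compounds below may be only part of what the source reports. "The series", "measured", "known", "first", "only" and "open" are said of these compounds alone.

Compound 1 `COc1cc2[nH]c(C)c(-c3ccc(Oc4ccc(OC(F)(F)F)c(F)c4)cc3)c(=O)c2cc1Cl` is reported in an ADME assay on HepG2 cells (Homo sapiens) for cytotoxicity, read by resazurin assay, with a stated time of 24 h (on this read-out higher numbers stand for weaker inhibition and lower numbers for stronger inhibition), only as a limit, > 10000 nM. Compound 2 `Cc1[nH]c2ccccc2c(=O)c1-c1ccc(Oc2ccc(OC(F)(F)F)cc2)nc1` is likewise reported in this assay only as a limit, > 10000 nM. Compound 3 `COc1cc2[nH]c(C)c(-c3ccc(Oc4ccc(Cl)cc4)cc3)c(=O)c2cc1Cl` stands in this assay only as a limit as well, > 10000 nM. Compound 3 thus sits at the limit of > 10000 nM in this assay, at which 3 of the 3 values shown sit, so no ordering among the three measured compounds can be drawn from these numbers. Compound 4 `COc1cc2[nH]c(C)c(-c3ccc(Oc4ccc(C(F)(F)F)cn4)cc3)c(=O)c2cc1Cl` differs from compound 3 by 5-(trifluoromethyl)pyridin-2-yl in place of 4-chlorophenyl on an oxygen on an aromatic ring. Going by the values given here, no step between measured compounds in this assay is available, and with every value resting at the limit, the step that the limit leaves unreadable from compound 3 to compound 4 is expected to be none beyond the scatter. Compound 4 is estimated at 15000 nM, with a range from 8000 nM to 50000 nM, most likely reported again as a limit.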

Compound 4, half-maximal inhibitory concentration: > 10000 nM
Compound 4: no number, only a limit; the forecaster's own chance of this, stated with the estimate: 85%; the middle value is on the limit's open side.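

Going by these compounds alone, compound 3 and compound 4 both stand only as limits in this assay, and no step between them can be read. The compounds shown leave open whether any structural change alters this read-out: the limit of > 10000 nM in this assay, at which 4 of the 4 values shown sit.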